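Chloro for methyl on compound 2: working notes

A few compounds are considered here, and "the series" means these few. Any claim that something is new, unique, unknown or untested is made for them only; others in the source may bear on it.

In a functional assay on HepG2 cells (Homo sapiens) for inhibition, read by MTT assay, with a stated time of 48 h (a lower number here means a stronger inhibitor, a higher number a weaker inhibitor), compound 2 (`Cc1ccc(/C=C2\SC(=O)N(CC(=O)Nc3c(C)n(C)n(-c4ccccc4)c3=O)C2=O)cc1`) gives 57600 nM as the higher of two numbers, and compound 1 (`COc1ccc(/C=C2\SC(=O)N(CCNC(=O)Nc3c(C)n(C)n(-c4ccccc4)c3=O)C2=O)cc1`) gives 8370 nM as the lower, a gap beyond the scatter. Compound 3 (`Cc1c(NC(=O)CN2C(=O)S/C(=C\c3ccc(Cl)cc3)C2=O)c(=O)n(-c2ccccc2)n1C`) has chloro in place of methyl on an aromatic carbon, para to a large group (chloro in place of methyl on an aromatic carbon). Going by the values given here, no measured pair shows this change, so no step beyond the scatter is expected in this assay for this replacement. The estimated step (a 1.3-fold lower number from compound 2 to compound 3 (0.11 log units; within the scatter)) is small. The estimate for compound 3 is 45000 nM with an expected range (18000 nM to 110000 nM).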

Compound 3, half-maximal inhibitory concentration: 31900 nM
Estimate against measurement, compound 3: 1.4-fold (0.15 log units) above; the measured number falls inside the stated range.
By their numbers in this assay, from the lowest: compound 1; then compounds 3 and 2 (each within the scatter of the next).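

In this assay, going by these compounds alone, the replacement of 4-methylphenyl by 4-chlorophenyl gives the first one-place comparison (a 1.8-fold lower number from compound 2 to compound 3 (0.26 log units; within the scatter)). At this aromatic carbon, chloro and methyl therefore cannot be told apart in this assay. No measurement on hand bears on why this is so.

Open, going by these compounds, is whether an amine or a carboxylic acid at this same carbon would give a step beyond the scatter. Also open, on these data alone, is how a longer chain between the shared core and the other ring system would read against compound 2.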